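Moving a methyl on the sulfonamide aryl group

The compounds below may be only part of what the source reports. "The series", "measured", "known", "first", "only" and "open" are said of these compounds alone.

Three sulfonamides built on a shared core have been tested in a functional assay on MCF7 cells (Homo sapiens) for antiproliferative activity, read by sulforhodamine B assay, with a stated time of 48 h; on this read-out higher numbers stand for weaker inhibition and lower numbers for stronger inhibition. Compound 1 `O=C1NCCN1c1ccc(S(=O)(=O)Nc2ccc3[nH]ccc3c2)cc1` gives 170 nM. Compound 2 `Cc1ccc(NS(=O)(=O)c2ccc(N3CCNC3=O)cc2)cc1C` gives 230 nM, and compound 3 `CCCCOc1ccc(NS(=O)(=O)c2ccc(N3CCNC3=O)cc2)cc1` gives 870 nM. Among these three numbers compound 2 stands second highest: its value and that of compound 1 lie within the scatter of one another, so nothing separates the two, while the value of compound 3 lies beyond the scatter above it, so compound 3 is the weaker of that pair.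

The next compound, compound 4 `Cc1ccc(NS(=O)(=O)c2ccc(N3CCNC3=O)cc2)c(C)c1`, has the same atoms as compound 2 joined differently: 2,4-dimethylphenyl in place of 3,4-dimethylphenyl on a sulfonamide nitrogen. Among the compounds with values here, no measured pair in this set shows such a change, so the size of its effect is not known from these data. The surrounding numbers suggest that the arylsulfonamide tolerates several aryl groups without large movement, and the account expects for compound 4 a small loss in this assay, a step of a 1.7-fold higher number from compound 2 to compound 4 (0.24 log units; within the scatter) that may or may not exceed the scatter. On that basis compound 4 is estimated at 400 nM in this assay, with a range from 150 nM to 1200 nM.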

Compound 4, half-maximal inhibitory concentration: 230 nM
Compound 4: the middle estimate sits 1.7-fold (0.24 log units) above what was measured; measured number inside the range.
By their numbers in this assay, from the lowest: compounds 1, 2 and 4 (each within the scatter of the next); then compound 3.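

In this assay, within the data shown here, the use of 2,4-dimethylphenyl in place of 3,4-dimethylphenyl on a sulfonamide nitrogen gives no change at the digits printed from compound 2 to compound 4 (within the scatter) and so supplies the first comparison in this set between two compounds that differ in one place. The earlier compounds shown here carried different aryl groups and could not show what a rearrangement of the same two methyl groups does; this pair shows that, for these two dimethylphenyl groups, the rearrangement leaves no effect that can be told from the scatter of the measurement. No independent measurement bears on this result, and the data offer no account of it.

This finding rests on a single pair and covers only these two arrangements of two methyl groups, so it cannot be extended to the sulfonamide aryl group as a whole. The compounds shown leave open how the number would respond to a plain phenyl ring, to a single methyl group, or to a carboxylic acid or an amine on the ring, and whether a longer chain in place of either methyl group would give a step beyond the scatter.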